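Replacing the Amino Chain of Compound 1 with an Ether

The compounds below may be only part of what the source reports. "The series", "measured", "known", "first", "only" and "open" are said of these compounds alone.

In a physicochemical assay for permeability, using PAMPA, with a stated time of 3 h, at pH 7.4 (a higher number here means that the compound crosses the layer faster, a lower number that the compound crosses the layer more slowly), compound 1 `CCOC(=O)CCNc1cc(Nc2ccc3[nH]c(=O)[nH]c3c2)c(Cl)cc1[N+](=O)[O-]` gives 151 nm/s. Compound 2 `O=c1[nH]c2ccc(Nc3cc(NCc4cccnc4)c([N+](=O)[O-])cc3Cl)cc2[nH]1` gives 147 nm/s, so the two stand level within the scatter. Compound 3 `O=c1[nH]c2ccc(Nc3cc(OC4CCOCC4)c([N+](=O)[O-])cc3Cl)cc2[nH]1` has not yet been measured, and its change is (oxan-4-yl)oxy in place of (2-(ethoxycarbonyl)ethyl)amino on an aromatic carbon. Among the measured compounds shown here, the only measured step, a 1.0-fold lower number from compound 1 to compound 2 (0.01 log units; within the scatter), altered the same chain but kept its nitrogen link, and it stayed within the scatter. For the measured compounds named here, no measured step replaces that link, so this evidence is thin. The expected step is a 1.0-fold lower number from compound 1 to compound 3 (0.00 log units; within the scatter), which means none beyond the scatter. Compound 3 is estimated at 150 nm/s, with an expected range of 60 nm/s to 380 nm/s.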

Compound 3, apparent permeability: 45 nm/s
For compound 3 the middle estimate is 3.3-fold (0.52 log units) above the measured one; measured number below the stated range.
By their numbers in this assay, from the lowest: compound 3; then compounds 2 and 1 (each within the scatter of the next).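

In this assay the group on this aromatic carbon, ortho to a nitro group, now proves able to shift the number: (oxan-4-yl)oxy gives a 3.4-fold lower number from compound 1 to compound 3 (0.53 log units; beyond the scatter) when it replaces (2-(ethoxycarbonyl)ethyl)amino, and a 3.3-fold lower number from compound 2 to compound 3 (0.51 log units; beyond the scatter) when it replaces ((pyridin-3-yl)methyl)amino. The earlier change, which kept the nitrogen link, stayed within the scatter. No measurement here accounts for this drop.
The oxygen link and the ring arrive together, so the compounds shown leave open which of them goes with the step. An (oxan-4-yl)amino group, with the same ring on a nitrogen, would separate the two.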